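This account rests on a few compounds, and the source may have more. Where it says the series, first, only, none or still open, it means among the compounds named here.

Measured in a functional assay on PC-3 cells (Homo sapiens) for antiproliferative activity, read by WST assay, with a stated time of 3 days (on this read-out lower numbers stand for stronger inhibition and higher numbers for weaker inhibition), so far:
- compound 1 `CCCCCOc1c(-c2cc(OC)c(OC)c(OC)c2)oc2ccccc2c1=O` gives 22200 nM
- compound 2 `COc1cc(-c2oc3ccccc3c(=O)c2OC(C)C)cc(OC)c1OC` gives 21200 nM
- compound 3 `CCC(C)Oc1c(-c2cc(OC)c(OC)c(OC)c2)oc2ccccc2c1=O` gives 38600 nM

Compound 3 stands level with the other two, with a 1.7-fold higher number from compound 1 to compound 3 (0.24 log units; within the scatter) and a 1.8-fold higher number from compound 2 to compound 3 (0.26 log units; within the scatter) as its steps. Next comes compound 4 (`CCCN(CCC)CCCOc1c(-c2cc(OC)c(OC)c(OC)c2)oc2ccccc2c1=O`), which has 3-(dipropylamino)propyl in place of sec-butyl on an oxygen on an aromatic ring. For the measured compounds named here, the only evidence is the swaps among plain alkyl groups on that oxygen, including a 1.0-fold lower number from compound 1 to compound 2 (0.02 log units; within the scatter) as the third step, and none goes beyond the scatter. Going by the values given here, no measured compound has nitrogen in this chain, so these steps guide the new one only weakly. A moderate move to a lower number is tentatively expected, as an estimated 4.3-fold lower number from compound 3 to compound 4 (0.63 log units; beyond the scatter) in this assay with wide uncertainty. Compound 4 is estimated at 9000 nM (range 2500 nM to 30000 nM).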

Compound 4, half-maximal inhibitory concentration: 16800 nM
Compound 4: middle estimate off by 1.9-fold (0.27 log units), on the low side; the measured number falls inside the stated range.
By their numbers in this assay, from the lowest: compounds 4, 2, 1 and 3 (each within the scatter of the next, the first and the last beyond it).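

In this assay, for the compounds shown here, putting nitrogen in the chain on this oxygen is tolerated: 3-(dipropylamino)propyl in place of sec-butyl gives a 2.3-fold lower number from compound 3 to compound 4 (0.36 log units; beyond the scatter), the only step at this position so far that lies beyond the scatter, and it is modest. The same chain does not separate from the other two alkyl groups, with a 1.3-fold lower number from compound 2 to compound 4 (0.10 log units; within the scatter) and a 1.3-fold lower number from compound 1 to compound 4 (0.12 log units; within the scatter). Going by these compounds alone, no measurement bears on why the one step exceeds the scatter and the other two do not.

As far as these compounds go, whether the nitrogen or the chain length matters remains open. A plain octyl chain, or a morpholine or carboxylic acid at the end of a propyl chain, would test this.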